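The source may report more compounds than this note shows. Statements on the series, on what has been measured and on what is new or still open speak of the compounds shown alone.

In a functional assay on HT-29 cells (Homo sapiens) (a higher number here means that more compound is needed for the effect, a lower number that less compound is needed), compound 1 `CN(C)c1ccc(-c2cc(C(=O)N[C@H]3CCCNC3)c(NC(N)=O)s2)cc1` gives 90 nM, compound 2 `CS(=O)(=O)c1ccc(-c2cc(C(=O)N[C@H]3CCCNC3)c(NC(N)=O)s2)cc1` gives 200 nM, and compound 3 `NCCNC(=O)c1cc(-c2ccccc2)sc1NC(N)=O` gives 960 nM. Compound 2 therefore holds the second highest of the three numbers: compound 1 lies a step below it, and compound 3 stands furthest from it above. Within the data shown here, the one step measured so far between compound 1 and compound 2, a 2.2-fold higher number from compound 1 to compound 2 (0.35 log units; beyond the scatter), was modest. Compound 4 `NC(=O)Nc1sc(-c2ccc(C(=O)N3CCCCC3)cc2)cc1C(=O)N[C@H]1CCCNC1` is obtained from compound 2 by the change (piperidin-1-yl)carbonyl in place of methylsulfonyl on an aromatic carbon on an aromatic carbon of the six-membered carbon-only ring, para to a large group. Among the measured compounds shown here, no step among the measured compounds tests this exchange directly, so the account expects in this assay a step no larger than modest for compound 4, a 1.3-fold lower number from compound 2 to compound 4 (0.12 log units; within the scatter), with the estimate for compound 4 of 150 nM, ranging from 60 nM to 400 nM.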

Compound 4, half-maximal effective concentration: 130 nM
Estimate against measurement, compound 4: 1.2-fold (0.06 log units) above; measured number inside the range.
By their numbers in this assay, from the lowest: compounds 1, 4 and 2 (each within the scatter of the next, the first and the last beyond it); then compound 3.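

Both a 1.5-fold lower number from compound 2 to compound 4 (0.19 log units; within the scatter) on leaving methylsulfonyl and a 1.4-fold higher number from compound 1 to compound 4 (0.16 log units; within the scatter) on leaving dimethylamino lie within the scatter in this assay and so do not separate compound 4 from either neighbour. Among these compounds, this place, on the six-membered aromatic ring of carbon only, thus takes (piperidin-1-yl)carbonyl, the first group here to bring a non-aromatic ring, although methylsulfonyl and dimethylamino stand apart beyond the scatter. Nothing available explains this result.

Going by these compounds, whether a carboxylic acid, a primary amine or a longer chain at this place would stay in the same range remains open.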